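The compounds below may be only part of what the source reports. "The series", "measured", "known", "first", "only" and "open" are said of these compounds alone.

Compound 1 `O=c1ccoc2cc(OCc3cn(Cc4ccccc4)nn3)ccc12`: in a functional assay on A549 cells (Homo sapiens) for cytotoxicity, read by MTT assay, with a stated time of 48 h (a lower number here means a stronger inhibitor, a higher number a weaker inhibitor), compound 1 gives > 100000 nM, which is a limit of the assay and not a number.
Compound 2 `O=c1ccoc2cc(OCc3cn(Cc4cccc([N+](=O)[O-])c4)nn3)ccc12`: in this assay compound 2 gives 9450 nM.

Going by the values given here, compound 2 holds the only real number among the two values shown; compound 1 sits at the limit of > 100000 nM in this assay, at which 1 of the 2 values shown sits. Among the compounds with values here, the single measured step, an at least 10-fold lower number from compound 1 to compound 2 (1.02 log units; beyond the scatter), shows that placing a nitro group on the ring at the end of the chain turned a compound at the limit into one with a measurable value. Compound 3 `N#Cc1ccc(Cn2cc(COc3ccc4c(=O)ccoc4c3)nn2)cc1` differs from compound 2 by 4-cyanophenyl in place of 3-nitrophenyl on a saturated chain carbon bound to an aromatic nitrogen. Within the data shown here, no measured step compares these two groups directly, so the one measured step gives only indirect guidance: a substituted ring does better than a bare one, but the new group and its place on the ring are untested. Compound 3 is expected to give about 20000 nM, with a range from 6000 nM to 100000 nM, an expected step of a 2.1-fold higher number from compound 2 to compound 3 (0.33 log units; beyond the scatter), a small weakening or none beyond the scatter.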

Compound 3, half-maximal inhibitory concentration: > 100000 nM
Compound 3 ended at the assay's limit; the forecaster's own chance of this, stated with the estimate: 30%; middle value at least 5.0-fold (0.69 log units) away from the limit.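

In this assay, 4-cyanophenyl in place of 3-nitrophenyl on a saturated chain carbon bound to an aromatic nitrogen gives an at least 10-fold higher number from compound 2 to compound 3 (1.02 log units; beyond the scatter), so a substituent on this ring does not by itself give a measurable value. Compound 3 gives a limit of the assay and not a number, and it sits there with compound 1: the limit of > 100000 nM in this assay, at which 2 of the 3 values shown sit. Both of these values are limits, so the step between compound 1 and compound 3 cannot be read, and a nitrile on the ring shows no readable gain over the bare ring.

The change alters both the group and where it sits on the ring, so the compounds shown cannot separate these two effects. They also leave open how an amine or a carboxylic acid on this ring would compare with the nitro group.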